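A few compounds are considered here, and "the series" means these few. Any claim that something is new, unique, unknown or untested is made for them only; others in the source may bear on it.

Of the compounds shown here, three have been tested so far in an ADME assay on PA-1 cells (Homo sapiens) for cytotoxicity, read by MTT assay, with a stated time of 72 h; on this read-out lower numbers stand for stronger inhibition and higher numbers for weaker inhibition. Compound 1 `COc1cc(C2=C(c3cc(C)c(OC)c(C)c3)C(O)CC2=O)cc(OC)c1OC` carries a free hydroxy group on its saturated ring carbon. In this assay compound 1 gives only a limit of > 100 ug/mL. Compound 2 `COc1cc(C2=C(c3cc(C)c(OC)c(C)c3)C(OC(C)=O)CC2=O)cc(OC)c1OC` is its acetylated counterpart, and in this assay compound 2 likewise gives only a limit, > 100 ug/mL. Compound 3 `CC(=O)OC1C/C(=N/O)C(c2ccccc2)=C1c1ccccc1` is built on a different core; how this core differs from that of compound 2 is not broken down here. In this assay compound 3 also gives only a limit, > 100 ug/mL.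

The change from compound 2 to compound 1 is hydrogen in place of acetyl on an oxygen on a saturated carbon. Its step, a step that the two limits leave unreadable from compound 2 to compound 1, cannot be read because the limit of > 100 ug/mL in this assay, at which 3 of the 3 values shown sit, covers both values.

Compound 4 `O/N=C1/CC(O)C(c2ccccc2)=C1c1ccccc1` arises from compound 3 by the same change, (hydrogen in place of acetyl on an oxygen on a saturated carbon). The expected step here is a number no higher from compound 3 to compound 4 (the limit leaves the size open), resting on the limit of > 100 ug/mL in this assay, at which 3 of the 3 values shown sit, and on the unreadable a step that the two limits leave unreadable from compound 2 to compound 1. Compound 4 is estimated at 100 ug/mL, with a likely range from 40 ug/mL to 300 ug/mL, and it is expected that the assay may again report only a limit.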

Compound 4, half-maximal inhibitory concentration: > 100 ug/mL
Compound 4 was reported as a limit (the forecaster's own chance of this, stated with the estimate: 80%); the middle value sits exactly at the limit.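

No new step can be read from compound 3 to compound 4 in this assay, because both compounds are reported only as limits: the limit of > 100 ug/mL in this assay, at which 4 of the 4 values shown sit.

The compounds shown leave open whether the change from acetoxy to hydroxy alters the read-out in this assay at all, and none of them yet gives an actual number there.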